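From 3-cyanophenyl to 3-chlorophenyl: a small step expected

A few compounds are considered here, and "the series" means these few. Any claim that something is new, unique, unknown or untested is made for them only; others in the source may bear on it.

Of the compounds shown here, three sharing one core have been tested in a functional assay on PANC-1 cells (Homo sapiens) for inhibition, read by MTT assay, with a stated time of 24 h; a lower number here means a stronger inhibitor, a higher number a weaker inhibitor. Compound 1 (`CC1(C)[C@H]2CC[C@]1(C)N(Cc1cn(-c3cccc(F)c3)nn1)C(=O)C2`) gives 220 nM, compound 2 (`CC1(C)[C@H]2CC[C@]1(C)N(Cc1cn(-c3ccccc3C#N)nn1)C(=O)C2`) gives 240 nM, and compound 3 (`CC1(C)[C@H]2CC[C@]1(C)N(Cc1cn(-c3cccc(C#N)c3)nn1)C(=O)C2`) gives 260 nM. Compound 3 therefore lies within the scatter of both others, and the three cannot be ranked.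

Compound 4 (`CC1(C)[C@H]2CC[C@]1(C)N(Cc1cn(-c3cccc(Cl)c3)nn1)C(=O)C2`) has not been measured yet. It carries chloro in place of cyano on an aromatic carbon, meta to a large group: chloro in place of cyano on an aromatic carbon.

The closest measured change is a 1.2-fold higher number from compound 1 to compound 3 (0.07 log units; within the scatter), with cyano in place of fluoro on an aromatic carbon. Moving the nitrile gives a 1.1-fold higher number from compound 2 to compound 3 (0.03 log units; within the scatter), and the remaining pair shows a 1.1-fold higher number from compound 1 to compound 2 (0.04 log units; within the scatter). All three steps are small, but none of the tested compounds carries chloro, so the evidence is indirect. With these steps as a guide, no change beyond the scatter is expected in this assay. The expected change is a 1.1-fold lower number from compound 3 to compound 4 (0.05 log units; within the scatter). For compound 4 the estimated value is 230 nM, with an expected range of 120 nM to 450 nM.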

Compound 4, half-maximal inhibitory concentration: 260 nM
For compound 4 the middle estimate is 1.1-fold (0.05 log units) below the measured one; the measured number falls inside the stated range.
By their numbers in this assay, from the lowest: compounds 1, 2, 3 and 4 (each within the scatter of the next).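

Chloro can take the place of cyano at this position, meta to a large group, with no visible cost in this assay: the swap gives no change at the digits printed from compound 3 to compound 4 (within the scatter), even though a nitrile with its triple bond and hydrogen-bond acceptor leaves and a group with no hydrogen-bond acceptor enters. The other comparisons agree, with a 1.1-fold higher number from compound 2 to compound 4 (0.03 log units; within the scatter) and a 1.2-fold higher number from compound 1 to compound 4 (0.07 log units; within the scatter), so compound 4 does not stand apart from any of the three earlier compounds. No other measurement is available to explain why these compounds read alike.

The substituents shown on this aromatic ring are only fluoro, chloro and cyano, so an amine, a carboxylic acid or a longer alkyl chain at the same place could behave differently. Going by these compounds, whether any change at this position can move the number beyond the scatter in this assay remains open.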